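The source may hold more compounds than are shown below. What is called first, only, known or untested is meant among the compounds shown, and "the series" means these compounds.

Measured compounds:
Compound 1, `COc1ccc(CNC(=O)/C(C#N)=C/c2ccc(C)o2)cc1`: in a functional assay on NCI-H460 cells (Homo sapiens) for inhibition, read by MTT assay, with a stated time of 72 h (a lower number here means a stronger inhibitor of growth, a higher number a weaker inhibitor of growth), compound 1 gives > 100000 nM, a limit of the assay.
Compound 2, `COc1ccc(CNC(=O)/C(C#N)=C/c2ccc(Br)o2)cc1`: in this assay compound 2 gives 16000 nM.

Compound 2 holds the only number shown; the other value is a limit (the limit of > 100000 nM in this assay, at which 1 of the 2 values shown sits). Compound 3, `COc1ccc(CNC(=O)/C(C#N)=C/c2ccc(C)cc2)cc1`, differs by 4-methylphenyl in place of 5-bromofuran-2-yl on a double-bonded chain carbon bound to a double-bonded chain carbon. Among the measured compounds shown here, the one measured step, an at least 6.2-fold lower number from compound 1 to compound 2 (0.79 log units; beyond the scatter), put bromo on the furan; compound 3 loses that bromine and the furan together, so a weaker inhibitor is expected, with a 3.8-fold higher number from compound 2 to compound 3 (0.57 log units; beyond the scatter) as the estimated step. Compound 3 is estimated at 60000 nM, between 15000 nM and 200000 nM.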

Compound 3, concentration for 50% growth inhibition: 41000 nM
The estimate for compound 3 lay 1.5-fold (0.17 log units) above the measured number; measured number inside the range.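

In this assay, 4-methylphenyl in place of 5-methylfuran-2-yl gives an at least 2.4-fold lower number from compound 1 to compound 3 (0.38 log units; beyond the scatter), so at this position a furan is not required for measurable growth inhibition. This step is only a bound, as compound 1 stands at a limit: the limit of > 100000 nM in this assay, at which 1 of the 3 values shown sits. Replacing 5-bromofuran-2-yl with 4-methylphenyl gives a 2.6-fold higher number from compound 2 to compound 3 (0.41 log units; beyond the scatter), leaving compound 2 the strongest inhibitor of the three. As far as these compounds go, what remains open is how a 4-bromophenyl group would compare, which would separate the contribution of the bromine from that of the furan, and how a ring carrying an amine or a carboxylic acid would fare.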